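This account rests on a few compounds, and the source may have more. Where it says the series, first, only, none or still open, it means among the compounds named here.

In a functional assay on HeLa cells (Homo sapiens) for cytotoxicity, read by ELISA, with a stated time of 2 days (a lower number here means a stronger inhibitor, a higher number a weaker inhibitor), three compounds sharing one core have been measured. Compound 1 (`Oc1ccccc1-c1cc(-c2ccccc2)cc(-c2ccccc2O)n1`) gives 14800 nM, and compound 2 (`Oc1cccc(-c2cc(-c3ccccc3)cc(-c3ccccc3)n2)c1`) gives 16100 nM. Compound 3 (`Oc1ccc(-c2cc(-c3ccccc3)cc(-c3ccccc3)n2)cc1`) gives 1700 nM, the lowest number of the three and clearly beyond the scatter from both others.

The next compound, compound 4 (`Oc1ccc(-c2cc(-c3ccccc3)cc(-c3ccc(O)cc3)n2)cc1`), differs from compound 3 by one change: hydroxy in place of hydrogen on an aromatic carbon. In other words, a phenyl becomes a 4-hydroxyphenyl, the same group that compound 3 already carries.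

Going by the values given here, only one measured step bears on this, a 9.5-fold lower number from compound 2 to compound 3 (0.98 log units; beyond the scatter), a modest change made by moving a hydroxy group rather than adding one. Among the compounds with values here, it shows that the place of the hydroxy group matters, but no measured pair shows what hydroxy in place of hydrogen does. No clear direction can therefore be drawn, and only a small shift is expected, namely a 1.1-fold lower number from compound 3 to compound 4 (0.05 log units; within the scatter). The estimated value for compound 4 is 1500 nM, with an expected range of 400 nM to 6000 nM.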

Compound 4, half-maximal inhibitory concentration: 3300 nM
Beside the measured number, compound 4's estimate is 2.2-fold (0.34 log units) below it; low and high end bracket the measured number.
By their numbers in this assay, from the lowest: compounds 3 and 4 (each within the scatter of the next); then compounds 1 and 2 (each within the scatter of the next).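

In this assay, going by these compounds alone, hydroxy in place of hydrogen on an aromatic carbon, turning a phenyl into a 4-hydroxyphenyl, gives a 1.9-fold higher number from compound 3 to compound 4 (0.29 log units; within the scatter), the first measured step for adding this group rather than moving it. A second 4-hydroxyphenyl therefore leaves the number within the scatter, whereas moving the hydroxy group gave a 9.5-fold lower number from compound 2 to compound 3 (0.98 log units; beyond the scatter), so in these compounds the place of the first hydroxy group shows a step beyond the scatter and adding a second does not. No measurement available here explains this result.

The compounds shown leave open whether an amine, a carboxylic acid or a methoxy group at this same place would also stay within the scatter of compound 3. They also leave open what any group does on the phenyl that compound 4 still carries.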